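Swapping a ring amine for an amide on the core

The compounds below may be only part of what the source reports. "The series", "measured", "known", "first", "only" and "open" are said of these compounds alone.

Measured so far:
- compound 1, `COC(=O)/C=C/c1ccc2noc(-c3ccccc3)c2c1`, 1580 nM
- compound 2, `CNC(=O)/C=C/c1ccc2noc(-c3ccccc3)c2c1`, 58200 nM
- compound 3, `O=C(O)c1ccc2noc(-c3ccc(N4CCCCC4)cc3)c2c1`, 240 nM

These three compounds share one core and were all tested in an assay for inhibition of inositol hexakisphosphate kinase 2 (Homo sapiens), read by colorimetric assay, coupled enzyme assay and malachite green, with a stated time of 120 min, in the presence of a further agent that is not named here; a lower number here means a stronger inhibitor, a higher number a weaker inhibitor. Compound 3 gives the lowest number of the three, so it is the strongest inhibitor here: compound 1 sits at 1580 nM, and compound 2 at 58200 nM is the furthest away.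

Going by the values given here, the only step that links two measured compounds at a single position is the one from compound 1 to compound 2, where a methylamino group replaces a methoxy group on a carbonyl carbon, giving a 37-fold higher number from compound 1 to compound 2 (1.57 log units; beyond the scatter). That change sits on a side chain, not on the phenyl ring where compound 4 differs.

Compound 4, `O=C(O)c1ccc2noc(-c3ccc(NC(=O)C4CCCC4)cc3)c2c1`, arises from compound 3 by (cyclopentylcarbonyl)amino in place of piperidin-1-yl on an aromatic carbon. Among the compounds with values here, no measured step touches this position, so the step from compound 1 to compound 2 offers no direct guide, and the expectation rests on compound 3 alone. The expected step is a 1.5-fold higher number from compound 3 to compound 4 (0.16 log units; within the scatter), so compound 4 is estimated at 350 nM, within 100 nM to 1500 nM.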

Compound 4, half-maximal inhibitory concentration: 190 nM
Compound 4: middle estimate off by 1.8-fold (0.27 log units), on the high side; the measured number falls inside the stated range.
By their numbers in this assay, from the lowest: compounds 4 and 3 (each within the scatter of the next); then compound 1; then compound 2.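

Placing (cyclopentylcarbonyl)amino in place of piperidin-1-yl, on an aromatic carbon para to a large group, gives a 1.3-fold lower number from compound 3 to compound 4 (0.10 log units; within the scatter) and so leaves the two compounds indistinguishable in this measurement. Going by these compounds alone, the only earlier step lay on a side chain and was large, whereas this first reading at the new position shows that two quite different groups can stand here without a shift beyond the scatter: the entering group swaps a six-membered ring holding one hetero atom for a five-membered ring of carbon only, and it adds a carbonyl and a hydrogen-bond donor. No outside evidence bears on why these two groups give such closely matched numbers.

The compounds shown leave open whether the ring in either group matters at all, which a plain amine or a small acetylamino group at this position would help to test, and whether the amide hydrogen matters, which an N-methyl amide would probe. They also leave open how far the carboxylic acid shared by compound 3 and compound 4 matters, a question that its methyl ester on the same core could address.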